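Benzyloxy on the core of compound 1

A few compounds are considered here, and "the series" means these few. Any claim that something is new, unique, unknown or untested is made for them only; others in the source may bear on it.

Measured so far:
- compound 1 `OC[C@H]1O[C@H](Oc2ccc(-n3ccc4ccccc43)cc2Cl)[C@@H](O)[C@@H](O)[C@@H]1O`: 31.5 ug/mL
- compound 2 `O=[N+]([O-])c1ccc2c(ccn2-c2ccc(O[C@H]3O[C@H](CO)[C@@H](O)[C@H](O)[C@@H]3O)c(Cl)c2)c1`: 1.4 ug/mL

In a physicochemical assay for solubility, using the shake flask method, measured as thermodynamic solubility, with a stated time of 2 h, at pH 6.5 (a lower number here means a less soluble compound, a higher number a more soluble compound), compound 1 holds the higher of the two numbers at 31.5 ug/mL. Compound 3 `OC[C@H]1O[C@H](Oc2ccc(-n3ccc4c(OCc5ccccc5)cccc43)cc2Cl)[C@@H](O)[C@@H](O)[C@@H]1O` has benzyloxy in place of hydrogen on an aromatic carbon. Within the data shown here, one measured step bears on this change, nitro in place of hydrogen on an aromatic carbon: a 23-fold lower number from compound 1 to compound 2 (1.35 log units; beyond the scatter). It involves a different group, so it is only a rough guide. A large step to a lower number is expected in this assay, perhaps somewhat smaller than that one. The expected result is a 7.9-fold lower number from compound 1 to compound 3 (0.90 log units; beyond the scatter). The estimate for compound 3 is 4 ug/mL, with an expected range of 1 ug/mL to 15 ug/mL.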

Compound 3, solubility: < 0.1 ug/mL
Compound 3: only a limit was reported (the forecaster's own chance of this, stated with the estimate: 10%); at least 40-fold (1.60 log units) between middle value and limit.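

In this assay, benzyloxy in place of hydrogen on an aromatic carbon gives an at least 310-fold lower number from compound 1 to compound 3 (2.49 log units; beyond the scatter). Compound 3 gives < 0.1 ug/mL, which is a limit of the assay and not a number, so the real size of the step is not fixed: the limit of < 0.1 ug/mL in this assay, at which 1 of the 3 values shown sits. Until now only nitro had been seen on the shared core, at a 23-fold lower number from compound 1 to compound 2 (1.35 log units; beyond the scatter); a second, much larger group on an aromatic carbon now also lowers the number. From the compounds shown here alone, whether an amine or a carboxylic acid on this aromatic carbon would keep the number near that of compound 1 stays open. Smaller ethers, such as methoxy, leave the same question open.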